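Xanthine series: alkyl for tetrazolyl at the five-membered ring

The source may report more compounds than this note shows. Statements on the series, on what has been measured and on what is new or still open speak of the compounds shown alone.

Compound 1 `CCC(CC)Nc1ncnc2c1ncn2C1O[C@H](CO)[C@@H](O)[C@H]1O` is the reference point of the set. In an assay on cell membranes for binding affinity to adenosine receptor A1 (Cavia porcellus), read by radioligand binding (a higher number here means a weaker inhibitor, a lower number a stronger inhibitor), compound 1 gives 0.75 nM. Compound 2 `CCCn1c(=O)c2nc(-c3nn[nH]n3)[nH]c2n(CCC)c1=O` belongs to a different core. In this assay compound 2 gives > 10000 nM, which is a limit of the assay and not a number. Compound 2 therefore stands at the weak end of what has been measured: the limit of > 10000 nM in this assay, at which 1 of the 2 values shown sits. Going by the values given here, no step between measured compounds is available for this core, so the two values shown only mark the two ends of the range.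

Compound 3 `CCCn1c(=O)c2nc(C(C)(C)CCC)[nH]c2n(CCC)c1=O` differs from compound 2 in one place: 1,1-dimethylbutyl in place of 2H-tetrazol-5-yl on an aromatic carbon. Since compound 2 sits at a limit, any number read for compound 3 would be a step toward stronger binding; the expected step from compound 2 to compound 3 is an at least 330-fold lower number from compound 2 to compound 3 (2.52 log units; beyond the scatter), well beyond the scatter. For compound 3 the estimate in this assay is 30 nM, with a range from 5 nM to 300 nM.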

Compound 3, inhibition constant: 25 nM
Compound 3: the middle estimate sits 1.2-fold (0.08 log units) above what was measured; the measured number falls inside the stated range.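

Going by these compounds alone, the five-membered ring position, on an aromatic carbon between two ring nitrogen atoms, is the first place on this core where a single change can be followed. Putting 1,1-dimethylbutyl there in place of 2H-tetrazol-5-yl gives an at least 400-fold lower number from compound 2 to compound 3 (2.60 log units; beyond the scatter) in this assay and brings the core from an assay limit to a real reading, so a group with no ring, 0 hydrogen-bond donors and 0 hydrogen-bond acceptors is accepted at this carbon. The step is a lower bound on the change and not its full size, since the value for compound 2 is a limit and not a number: the limit of > 10000 nM in this assay, at which 1 of the 3 values shown sits.

This single pair swaps the ring, the hydrogen-bond donor and acceptors, and the carbon chain all at once, so it cannot show which of these differences accounts for the step. On these data alone, how a straight pentyl chain, a cyclohexyl ring, an amine or a carboxylic acid would read at this carbon stays open, as does the effect of changing either propyl group on the core.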